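The compounds below may be only part of what the source reports. "The series", "measured", "known", "first", "only" and "open" are said of these compounds alone.

Compound 1 `O=c1cc(CSC(=S)N2CCCCC2)oc2cc(Cl)ccc12`: 3000 nM
Compound 2 `O=c1cc(CSC(=S)N2CCCCC2)oc2ccccc12`: > 25000 nM (a limit)
Compound 3 `Cc1ccc2c(=O)c(CSC(=S)N3CCCC3)coc2c1`: 1900 nM

In a functional assay on MDA-MB-435S cells (Homo sapiens) for antiproliferative activity, read by MTT assay, with a stated time of 72 h (a lower number here means a stronger inhibitor, a higher number a weaker inhibitor), compound 1 gives 3000 nM, the higher of the two plain numbers; compound 3 gives 1900 nM, a gap that lies within the scatter. Compound 2 reaches only the limit of the assay, > 25000 nM, as noted in the limit of > 25000 nM in this assay, at which 1 of the 3 values shown sits. Among the measured compounds shown here, the single measured step, an at least 8.3-fold higher number from compound 1 to compound 2 (0.92 log units; beyond the scatter), concerns a group on the aromatic part and not the ring on the thiocarbonyl carbon. Compound 4 `O=c1cc(CSC(=S)N2CCOCC2)oc2cc(Cl)ccc12` differs from compound 1 by morpholin-4-yl in place of piperidin-1-yl on a thiocarbonyl carbon. For the measured compounds named here, no measured step touches that position, so the change is expected to stay within the scatter, no change at the digits printed from compound 1 to compound 4 (within the scatter). Compound 4 is therefore estimated at 3000 nM, ranging from 1200 nM to 8000 nM.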

Compound 4, half-maximal inhibitory concentration: > 25000 nM
Compound 4: a limit, no number; the forecaster's own chance of this, stated with the estimate: 10%; middle value at least 8.3-fold (0.92 log units) from the limit.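

The ring on the thiocarbonyl carbon matters in this assay: the change gives an at least 8.3-fold higher number from compound 1 to compound 4 (0.92 log units; beyond the scatter). So this position can weaken the compound as much as removing the chloro group does, and swapping piperidin-1-yl for morpholin-4-yl is not a neutral exchange. Compound 4 gives a limit, not a number, so the full size of the loss is unknown, and compound 4 and compound 2 cannot be ordered: the limit of > 25000 nM in this assay, at which 2 of the 4 values shown sit.

As far as these compounds go, it remains open whether other rings at this position, such as piperazine or a dimethylamino group, would keep activity. From the compounds shown here alone, the effect of this swap on a core without the chloro group also remains open.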